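The compounds below may be only part of what the source reports. "The series", "measured", "known", "first", "only" and "open" are said of these compounds alone.

Compound 1 `CNC(=O)c1cc(Oc2cccc(NC(=S)Nc3ccc(Cl)cc3)c2)ccn1`: in a functional assay on MDA-MB-231 cells (Homo sapiens) for cytotoxicity, read by MTT assay, with a stated time of 48 h (a higher number here means a weaker inhibitor, a lower number a stronger inhibitor), compound 1 gives > 100000 nM, which is a limit of the assay rather than a number.
Compound 2 `O=C(NCc1ccccc1)c1cc(Oc2cccc(NC(=S)Nc3cccc(C(F)(F)F)c3)c2)ccn1`: in this assay compound 2 gives 75000 nM.
Compound 3 `CNC(=O)c1cc(Oc2cccc(NC(=S)Nc3ccc(OC(F)(F)F)cc3)c2)ccn1`: in this assay compound 3 gives > 100000 nM, again a limit rather than a number.

Compound 3 therefore has no fixed position among the values shown; it sits at the limit of > 100000 nM in this assay, at which 2 of the 3 values shown sit, and only a bound is known. For the measured compounds named here, the one step measured between compounds that differ in a single place, a step that the two limits leave unreadable from compound 1 to compound 3, runs between two limits and its size cannot be read.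

Compound 4 `O=C(NCc1ccccc1)c1cc(Oc2cccc(NC(=S)Nc3ccc(OC(F)(F)F)cc3)c2)ccn1` differs from compound 3 by phenyl in place of hydrogen on a saturated chain carbon bound to an amide-type nitrogen: a methylcarbamoyl group becomes a benzylcarbamoyl group. Going by the values given here, no measured step covers this change on its own. Among the compounds with values here, compound 2 is the only compound here that carries the benzylcarbamoyl group, and it is also the only one reported with a number rather than a limit; yet compound 2 differs from compound 3 in two places, so nothing can be attributed to the phenyl alone.

With no readable step to lean on, the expected step of an at least 1.2-fold lower number from compound 3 to compound 4 (0.09 log units; that floor lies within the scatter) is small and its direction uncertain. Compound 4 is estimated at 80000 nM, within a range from 30000 nM to 200000 nM, with a real chance that only a limit is reported.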

Compound 4, half-maximal inhibitory concentration: > 100000 nM
Compound 4 was reported as a limit; the forecaster's own chance of this, stated with the estimate: 40%; middle value at least 1.2-fold (0.09 log units) away from the limit.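

Adding the phenyl, which turns methylcarbamoyl into benzylcarbamoyl, does not bring a number out of this assay for the compound carrying 4-(trifluoromethoxy)phenyl; both compound 3 and compound 4 are reported only as limits, so the step between them cannot be read. With benzylcarbamoyl held fixed, the new comparison concerns the aromatic group on the amide-type nitrogen, and it gives an at least 1.3-fold higher number from compound 2 to compound 4 (0.12 log units; that floor lies within the scatter), so the data show only a floor that does not go beyond the usual scatter, and the true gap could be small or much larger. The benzylcarbamoyl group alone is therefore not enough to yield a measurable number, and the assay limit remains the most common result: the limit of > 100000 nM in this assay, at which 3 of the 4 values shown sit.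

Still open, as far as these compounds go, is whether another group in place of the benzyl, such as a longer chain or a chain ending in an amine or a carboxylic acid, would give a number clearly inside the range of the assay. Also open, from the compounds shown here alone, is how 3-(trifluoromethyl)phenyl would read alongside methylcarbamoyl, a pairing that would help separate the contributions of the two places in which compound 2 and compound 3 differ.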